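Macrocycle series: nitro replaced by hydrogen

A few compounds are considered here, and "the series" means these few. Any claim that something is new, unique, unknown or untested is made for them only; others in the source may bear on it.

Three macrocycles of one shared core have been measured in a functional assay on cell membranes from cells (Erythrocyte, Homo sapiens), read by spectrophotometry, with a stated time of 30 min, tested at 50 ug/mL; a higher number here means a stronger effect of the compound at the concentration tested, a lower number a weaker effect. Compound 1 `O=C1NCc2ccc(cc2)-c2cccc(c2)-c2ccc(cc2)CNC(=O)c2cccc(c2)OCc2ccc(cc2)COc2cccc1c2` gives 66.7% in this assay. Compound 2 `O=C1NCc2ccc(cc2)-c2cccc(c2)-c2ccc(cc2)CNC(=O)c2cccc(c2)OCc2ccccc2COc2cccc1c2` gives 73.3% in this assay. Compound 3 `O=C1NCc2ccc(cc2)-c2cccc(c2)-c2ccc(cc2)CNC(=O)c2cccc(c2)OCc2cc(cc([N+](=O)[O-])c2)COc2cccc1c2` gives 76% in this assay, the highest of the three numbers, though its distance to compound 2 and to compound 1 lies within the scatter, so no order among the three can be read from these values. Compound 4 `O=C1NCc2ccc(cc2)-c2cccc(c2)-c2ccc(cc2)CNC(=O)c2cccc(c2)OCc2cccc(c2)COc2cccc1c2` has not yet been measured in this assay. It differs from compound 3 in one place: hydrogen in place of nitro on an aromatic carbon. Among the compounds with values here, no pair of measured compounds differing in one place only is available, so the size of such a change cannot be read from a neighbouring step. All three measured numbers sit close together in this assay, and the change from compound 3 to compound 4 is expected to stay within the scatter, with an estimated step of a number 6 percentage points lower from compound 3 to compound 4 (within the scatter). Compound 4 is estimated at 70% in this assay, within a range of 58% to 82%.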

Compound 4, a percentage reported as activity, at one concentration (the size of the read-out at that concentration, not a potency): 72.5%
For compound 4 the middle estimate is 2.5 percentage points below the measured one, and the stated range covers the measured number.
By their numbers in this assay, from the lowest: compounds 1, 4, 2 and 3 (each within the scatter of the next).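

Compound 4 gives the series its first step in one place, and in this assay that step, hydrogen in place of nitro on an aromatic carbon meta to two fused rings, is small (a number 3.5 percentage points lower from compound 3 to compound 4 (within the scatter)). At this position, the read-out at the one tested concentration therefore stays within the scatter when the nitro group, with its three heavy atoms and two hydrogen-bond acceptors, is removed. No accompanying measurement bears on this step.

On these data alone, whether a different group on this aromatic carbon, such as an amine or a carboxylic acid, would give a step beyond the scatter remains open. A single concentration also leaves open whether compound 3 and compound 4 would stay this close at other concentrations.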